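Cytotoxicity Limits Along a Series of Cyclohexyl Substituents

The compounds below may be only part of what the source reports. "The series", "measured", "known", "first", "only" and "open" are said of these compounds alone.

Compound 1 `O=C(OC1CCC(CN2CCN(c3cc(=O)c4cc(C(F)(F)F)cc([N+](=O)[O-])c4s3)CC2)CC1)C1CCC1`, compound 2 `CC(C)S(=O)(=O)OC1CCC(CN2CCN(c3cc(=O)c4cc(C(F)(F)F)cc([N+](=O)[O-])c4s3)CC2)CC1` and compound 3 `O=c1cc(N2CCN(CC3CCC(OS(=O)(=O)c4cccnc4)CC3)CC2)sc2c([N+](=O)[O-])cc(C(F)(F)F)cc12` share one core and differ only in the group carried on an oxygen on a saturated carbon. In an ADME assay on Vero cells (Chlorocebus sabaeus) for cytotoxicity, read by MTT assay, with a stated time of 48 h (a higher number here means a weaker inhibitor, a lower number a stronger inhibitor), compound 1 gives only a limit, > 64 ug/mL. Compound 2 likewise gives only a limit, > 64 ug/mL. Compound 3 also reaches only a limit, > 64 ug/mL. Compound 3 thus stands together with the other two at the limit of > 64 ug/mL in this assay, at which 3 of the 3 values shown sit. The steps a step that the two limits leave unreadable from compound 1 to compound 2, a step that the two limits leave unreadable from compound 1 to compound 3 and a step that the two limits leave unreadable from compound 2 to compound 3 therefore cannot be sized. Compound 4 `CC(=O)NC1CCC(CN2CCN(c3cc(=O)c4cc(C(F)(F)F)cc([N+](=O)[O-])c4s3)CC2)CC1` differs from compound 3 by acetamido in place of ((pyridin-3-yl)sulfonyl)oxy on a saturated ring carbon. The three unreadable steps at this position bear on the change but give no size, so no step beyond the scatter is expected, and the estimated step is a number no higher from compound 3 to compound 4 (the limit leaves the size open). Compound 4 is therefore expected to give about 64 ug/mL, between 30 ug/mL and 130 ug/mL.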

Compound 4, half-maximal inhibitory concentration: > 64 ug/mL
Compound 4: a limit, no number; the forecaster's own chance of this, stated with the estimate: 80%; the middle value lies on the limit itself.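

Compound 4 also gives only a limit in this assay, so its steps from compound 1, compound 2 and compound 3 cannot be read: the limit of > 64 ug/mL in this assay, at which 4 of the 4 values shown sit. The compounds shown leave open whether the group at this place changes the reading in this assay at all.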